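Swapping Propyl for Fluorophenyl: Little Change Expected

This account rests on a few compounds, and the source may have more. Where it says the series, first, only, none or still open, it means among the compounds named here.

Measured so far:
Compound 1, `COc1nc2ccc(Br)cc2cc1C(c1ccccc1)n1cc(-c2ccccc2)nn1`, gives 5.97%
Compound 2, `CCCCCCCCc1cn(C(c2ccccc2)c2cc3cc(Br)ccc3nc2OC)nn1`, gives 2.27%
Compound 3, `CCCc1cn(C(c2ccccc2)c2cc3cc(Br)ccc3nc2OC)nn1`, gives 8.3%

These three compounds share one core and were tested in an ADME assay on PC-3 cells (Homo sapiens) for cytotoxicity, read by sulforhodamine B assay, with a stated time of 48 h, tested at 10 uM; on this read-out lower numbers stand for less inhibition and higher numbers for more inhibition at the one concentration tested (going by the name of the read-out). Compound 3 holds the highest of the three numbers, but the step of a number 2.3 percentage points higher from compound 1 to compound 3 (within the scatter) and the step of a number 6 percentage points higher from compound 2 to compound 3 (within the scatter) both sit within the scatter, so the three values cannot be told apart; all three show only slight inhibition.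

Compound 4, `COc1nc2ccc(Br)cc2cc1C(c1ccccc1)n1cc(-c2ccc(F)cc2)nn1`, differs from compound 3 by 4-fluorophenyl in place of propyl on an aromatic carbon. The step that bears most directly on this change is a number 2.3 percentage points higher from compound 1 to compound 3 (within the scatter), which shows that replacing phenyl with propyl at this carbon moved the number by almost nothing. Compound 4 is, in effect, compound 1 with a fluorine on that phenyl. The step of a number 3.7 percentage points lower from compound 1 to compound 2 (within the scatter) likewise shows that a very different group at the same carbon left the read-out essentially unchanged. It is therefore expected that the step of a number 2.3 percentage points lower from compound 3 to compound 4 (within the scatter) stays within the scatter. Compound 4 is estimated at 6%, with a range from 0% to 14%.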

Compound 4, a percentage reported as inhibition, at one concentration (the size of the read-out at that concentration, not a potency): 16.4%
Compound 4: middle estimate off by 10.4 percentage points, on the low side; measured number outside the range, above it.
By their numbers in this assay, from the lowest: compounds 2, 1, 3 and 4 (each within the scatter of the next, the first and the last beyond it).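

In this assay, going by these compounds alone, a single fluoro added to the phenyl group is the first change at this aromatic carbon to come out beyond the scatter (a number 10.4 percentage points higher from compound 1 to compound 4 (beyond the scatter)), so a small edit to the group can matter more here than the earlier swaps suggested. The 4-fluorophenyl group also stands clear of octyl (a number 14.1 percentage points higher from compound 2 to compound 4 (beyond the scatter)), but not of propyl (a number 8.1 percentage points higher from compound 3 to compound 4 (within the scatter)), so the gain is modest and does not separate it from all the earlier groups. Nothing measured here accounts for the effect of the fluoro.

The compounds shown leave open whether chloro or methoxy in place of the fluoro would give a similar number, and whether an amine or a carboxylic acid at this carbon would shift it. From the compounds shown here alone, it also remains open whether the fluoro step would hold at other concentrations.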